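A few compounds are considered here, and "the series" means these few. Any claim that something is new, unique, unknown or untested is made for them only; others in the source may bear on it.

Measured compounds and their values in a functional assay on HEL cells (Homo sapiens) for cytotoxicity, read by microscopy; on this read-out higher numbers stand for lower toxicity in this test and lower numbers for higher toxicity in this test:
- compound 1, `Cc1cn([C@@H]2O[C@H](CO[Si](C)(C)C(C)(C)C)[C@@]3(OS(=O)(=O)C=C3NCC(N)=O)[C@H]2O[Si](C)(C)C(C)(C)C)c(=O)n(C)c1=O`, gives 16000 nM
- compound 2, `CCOC(=O)NC(=O)NC1=CS(=O)(=O)O[C@@]12[C@@H](CO[Si](C)(C)C(C)(C)C)O[C@@H](n1cc(C)c(=O)n(C)c1=O)[C@@H]2O[Si](C)(C)C(C)(C)C`, gives 16000 nM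
- compound 3, `Cc1cn([C@@H]2O[C@H](CO[Si](C)(C)C(C)(C)C)[C@@]3(OS(=O)(=O)C=C3NC(=O)c3ccccc3)[C@H]2O[Si](C)(C)C(C)(C)C)c(=O)n(C)c1=O`, is reported only as a limit, >= 3200 nM

Going by the values given here, compound 2 sits level with compound 1, the only other compound with a full number, since no change at the digits printed from compound 1 to compound 2 (within the scatter). The two remaining comparisons cannot be read, because the limit of >= 3200 nM in this assay, at which 1 of the 3 values shown sits: from compound 1 to compound 3 the step is a step that the limit leaves unreadable from compound 1 to compound 3, and from compound 2 to compound 3 it is a step that the limit leaves unreadable from compound 2 to compound 3.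

Compound 4, `COC(=O)C(=O)CNC1=CS(=O)(=O)O[C@@]12[C@@H](CO[Si](C)(C)C(C)(C)C)O[C@@H](n1cc(C)c(=O)n(C)c1=O)[C@@H]2O[Si](C)(C)C(C)(C)C`, has not yet been measured. It differs from compound 2 by ((methoxycarbonyl)carbonyl)methyl in place of (ethoxycarbonyl)carbamoyl on an amine nitrogen. Among the compounds with values here, the one readable step, from compound 1 to compound 2, changed the group on the same amine nitrogen and gave no change beyond the scatter; the other two steps give no usable size. On that basis the step from compound 2 to compound 4 is expected to stay within the scatter, no change at the digits printed from compound 2 to compound 4 (within the scatter), in no particular direction. The estimate for compound 4 in this assay is therefore 16000 nM, with a range from 6000 nM to 40000 nM.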

Compound 4, minimum cytotoxic concentration: > 400000 nM
Compound 4: no number, only a limit; the forecaster's own chance of this, stated with the estimate: 30%; middle value at least 25-fold (1.39 log units) away from the limit.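

In this assay compound 4 is reported only as a limit, > 400000 nM. Going by these compounds alone, the one earlier readable change on this amine nitrogen gave no change at the digits printed from compound 1 to compound 2 (within the scatter), yet the new group gives an at least 25-fold higher number from compound 2 to compound 4 (1.39 log units; beyond the scatter), and also an at least 25-fold higher number from compound 1 to compound 4 (1.39 log units; beyond the scatter), so what this nitrogen carries can matter a great deal for toxicity in this test. The step from compound 1 is the narrower of the two, methoxycarbonyl in place of amino on a carbonyl carbon, so that single swap on an otherwise unchanged group is enough for a large step.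

The steps that involve compound 3 cannot be read, so benzoyl on this nitrogen cannot yet be placed against the ((methoxycarbonyl)carbonyl)methyl group. It also stays open whether the large step needs the methoxycarbonyl itself or would persist with a carboxylic acid, an ethyl ester or a longer chain in its place, and the series shown holds no compound that settles this on the shared core.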